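This account rests on a few compounds, and the source may have more. Where it says the series, first, only, none or still open, it means among the compounds named here.

Of the compounds shown here, two have been measured in an assay (Equus caballus) for inhibition of Thromboxane-A synthase (Homo sapiens), using microsomes; a higher number here means a weaker inhibitor, a lower number a stronger inhibitor. Compound 1, `O=C(O)CCC/C=C(/c1ccccc1)c1cccnc1`, carries a carboxylic acid at the end of its chain and gives 280 nM. Compound 2, `NC(=O)CCCC/C=C(\c1ccccc1)c1cccnc1`, ends in a primary amide and gives 400 nM. Compound 2 thus has the higher of the two numbers, but its value sits only a small distance from that of compound 1, and that distance falls within the scatter of repeated measurements, so the two compounds cannot be told apart on these numbers.

Compound 3, `CSC(CCC/C=C(\c1ccccc1)c1cccnc1)C(=O)O`, has not yet been measured. It differs from compound 2 in one place: carboxy(methylsulfanyl)methyl in place of carbamoylmethyl on a saturated chain carbon, three bonds along the chain from a double-bonded chain carbon. The chain therefore ends in a carboxylic acid again, with a methylsulfanyl group on the carbon that bears it. Among the measured compounds shown here, no measured pair shows the effect of such a change, so the step is expected to be modest, most likely towards a lower number, because compound 1 with its acid end gives 280 nM. The step of a 2.0-fold lower number from compound 2 to compound 3 (0.30 log units; within the scatter) is the expected outcome, and compound 3 is estimated at 200 nM, within a range from 60 nM to 650 nM.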

Compound 3, half-maximal inhibitory concentration: 30 nM
For compound 3 the middle estimate is 6.7-fold (0.82 log units) above the measured one; measured number below the stated range.
By their numbers in this assay, from the lowest: compound 3; then compounds 1 and 2 (each within the scatter of the next).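

In this assay, replacing carbamoylmethyl with carboxy(methylsulfanyl)methyl gives a 13-fold lower number from compound 2 to compound 3 (1.12 log units; beyond the scatter) and so moves the number well beyond the scatter. Among the compounds shown here, the earlier compounds could not be told apart, so this is the first sign that the group on this saturated chain carbon, three bonds along the chain from a double-bonded chain carbon, can strongly change the measured inhibition. Nothing available explains why the number falls so far.

The change replaces the primary amide with a carboxylic acid and adds a methylsulfanyl group in a single step, so the compounds shown cannot divide the drop between those two parts. A matched pair carrying the methylsulfanyl group on the amide chain, or the same acid chain with a hydrogen in its place, would separate them, while a methoxy or ethylsulfanyl group at that carbon would test whether the sulfur or the size of the group matters.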